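Aryl ketones on the shared core: thiophene to thiazole

This account rests on a few compounds, and the source may have more. Where it says the series, first, only, none or still open, it means among the compounds named here.

Measured so far in a functional assay on BXPC-3 cells (Homo sapiens) for antiproliferative activity, read by sulforhodamine B assay, with a stated time of 72 h (on this read-out lower numbers stand for stronger inhibition and higher numbers for weaker inhibition), are:
- compound 1 `CC(C)(C)c1[nH]cnc1/C=c1\[nH]c(=O)/c(=C/c2cccc(C(=O)N3CCCCC3)c2)[nH]c1=O` at 100 nM
- compound 2 `CC(C)(C)c1[nH]cnc1/C=c1\[nH]c(=O)/c(=C/c2cccc(C(=O)c3cccnc3)c2)[nH]c1=O` at 4.05 nM
- compound 3 `CC(C)(C)c1[nH]cnc1/C=c1\[nH]c(=O)/c(=C/c2cccc(C(=O)c3cccs3)c2)[nH]c1=O` at 1.72 nM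

Compound 3 stands lowest of the three. The next structure is compound 4 `CC(C)(C)c1[nH]cnc1/C=c1\[nH]c(=O)/c(=C/c2cccc(C(=O)c3cncs3)c2)[nH]c1=O` and the difference is 1,3-thiazol-5-yl in place of thiophen-2-yl on a carbonyl carbon. Among the measured compounds shown here, the closest precedent is the only measured swap of one aromatic ring for another, a modest step of a 2.4-fold lower number from compound 2 to compound 3 (0.37 log units; beyond the scatter) in that comparison. The large steps of a 25-fold lower number from compound 1 to compound 2 (1.39 log units; beyond the scatter) and a 58-fold lower number from compound 1 to compound 3 (1.76 log units; beyond the scatter) both start from piperidin-1-yl, so they bear less on this change. In this assay a small step toward a higher number is therefore expected, perhaps none beyond the scatter. The estimated change is a 1.7-fold higher number from compound 3 to compound 4 (0.24 log units; within the scatter) as a working figure. For compound 4 the expected value is 3 nM with an estimated range of 1 nM to 9 nM for the coming measurement.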

Compound 4, half-maximal inhibitory concentration: 17.1 nM
For compound 4 the middle estimate is 5.7-fold (0.76 log units) below the measured one, outside the stated range (above it).
By their numbers in this assay, from the lowest: compound 3; then compound 2; then compound 4; then compound 1.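

In this assay, a single added ring nitrogen on this carbonyl carbon costs far more than the earlier ring swap suggested: a 9.9-fold higher number from compound 3 to compound 4 (1.00 log units; beyond the scatter). The ring nitrogen alone does not set the rank, since 1,3-thiazol-5-yl also falls short of pyridin-3-yl, which carries one too: a 4.2-fold higher number from compound 2 to compound 4 (0.63 log units; beyond the scatter). The aromatic ketone still keeps its edge over the piperidine amide, with a 5.8-fold lower number from compound 1 to compound 4 (0.77 log units; beyond the scatter).

Nothing available explains why this ring swap costs so much. As far as these compounds go, whether furan-2-yl or plain phenyl on the same carbonyl carbon would match compound 3 remains open.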